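This account rests on a few compounds, and the source may have more. Where it says the series, first, only, none or still open, it means among the compounds named here.

Working notes on the series, all in a functional assay on NB1 cells (Homo sapiens) for cytotoxicity, read by MTT assay, with a stated time of 3 days; on this read-out higher numbers stand for weaker inhibition and lower numbers for stronger inhibition. Compound 1 `N#Cc1c(NN)nc(SCc2nc3ccccc3[nH]2)nc1-c1ccccc1` gives 5.4 nM, compound 2 `CCNc1nc(SCc2nc3ccccc3[nH]2)nc(-c2ccccc2)c1C#N` gives 2.63 nM, and compound 3 `N#Cc1c(NC(N)=S)nc(SCc2nc3ccccc3[nH]2)nc1-c1ccccc1` gives 11.9 nM. Compound 3 therefore holds the highest of the three numbers and is the weakest inhibitor measured so far.

The next compound is compound 4 `N#Cc1c(NC(N)=O)nc(SCc2nc3ccccc3[nH]2)nc1-c1ccccc1`, and the change is a group of 3 heavy atoms (1 carbon, 1 nitrogen, 1 oxygen; no ring) in place of a group of 3 heavy atoms (1 carbon, 1 nitrogen, 1 sulfur; no ring), on a nitrogen on an aromatic ring. Within the data shown here, no measured step exchanges sulfur for oxygen, so the evidence is indirect. All three measured steps change the group on this same nitrogen: a 2.1-fold lower number from compound 1 to compound 2 (0.31 log units; beyond the scatter), a 2.2-fold higher number from compound 1 to compound 3 (0.34 log units; beyond the scatter) and a 4.5-fold higher number from compound 2 to compound 3 (0.66 log units; beyond the scatter). Each is modest, even though the groups exchanged in them differ in heavy-atom count, whereas the groups in the coming change match in that count. A small shift is therefore expected, with no step beyond the scatter in this assay.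

The expected result is a 1.3-fold lower number from compound 3 to compound 4 (0.12 log units; within the scatter). Compound 4 is estimated at 9 nM, with an expected range of 3 nM to 28 nM.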

Compound 4, half-maximal inhibitory concentration: 7.35 nM
Beside the measured number, compound 4's estimate is 1.2-fold (0.09 log units) above it, and the stated range covers the measured number.
By their numbers in this assay, from the lowest: compound 2; then compounds 1, 4 and 3 (each within the scatter of the next, the first and the last beyond it).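

In this assay, oxygen in place of sulfur in the group on this nitrogen gives a 1.6-fold lower number from compound 3 to compound 4 (0.21 log units; within the scatter), so this exchange between groups of equal heavy-atom count leaves the read-out within the scatter. Carbamoyl in place of amino gives a 1.4-fold higher number from compound 1 to compound 4 (0.13 log units; within the scatter), also within the scatter, whereas carbamoyl in place of ethyl gives a 2.8-fold higher number from compound 2 to compound 4 (0.45 log units; beyond the scatter), so among these steps to compound 4 only the one from the ethyl compound lies beyond the scatter. Nothing available explains these differences.

Still open, as far as these compounds go, is whether a longer chain such as propyl or butyl on this nitrogen would follow ethyl or fall nearer carbamoyl. Also open, from the compounds shown here alone, is how an acetyl group, which keeps the carbonyl but lacks the terminal nitrogen of carbamoyl, would compare with compound 4.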